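This account rests on a few compounds, and the source may have more. Where it says the series, first, only, none or still open, it means among the compounds named here.

In an ADME assay on HEK-293T cells (Homo sapiens) for cytotoxicity, read by MTT assay, with a stated time of 48 h (a higher number here means that more compound is tolerated, a lower number that less compound is tolerated), the question asked of each compound is how much of it a human kidney-derived cell line can tolerate before the cells stop converting the dye used for the read-out. Compound 1 `Cn1cc(C2CC(c3ccc(F)cc3)=NN2C(=O)c2cccnc2)c2cc(Br)ccc21` carries a fluoro group on one of its aromatic rings and a bromo group on its core. In this assay compound 1 reaches only the limit of the measurement, > 300000 nM. Compound 2 `Cn1cc(C2CC(c3ccc(Cl)cc3)=NN2C(=O)c2cccnc2)c2cc(Br)ccc21` differs from compound 1 in a single place: chloro in place of fluoro on an aromatic carbon. In this assay compound 2 likewise gives only a limit, > 300000 nM. The step that this change made, a step that the two limits leave unreadable from compound 1 to compound 2, cannot be read, since both values are limits rather than numbers.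

Compound 3 `COc1ccc2c(c1)c(C1CC(c3ccc(F)cc3)=NN1C(=O)c1ccc(OC)nc1)cn2C` shares the fluoro-bearing ring of compound 1 but sits on a different core with methoxy groups in place of the bromo group; the difference between the two cores is not broken down here. In this assay compound 3 also gives only a limit, > 300000 nM.

Compound 4 `COc1ccc2c(c1)c(C1CC(c3ccc(Cl)cc3)=NN1C(=O)c1ccc(OC)nc1)cn2C` is to compound 3 what compound 2 is to compound 1: chloro in place of fluoro on an aromatic carbon, made at the same place and of the same kind. Within the data shown here, because the limit of > 300000 nM in this assay, at which 3 of the 3 values shown sit, holds for every measured compound, there is no measured step to lean on. The step from compound 3 to compound 4 is therefore expected to be flat, a step that the limit leaves unreadable from compound 3 to compound 4, and compound 4 is expected to sit again at the limit, near 400000 nM, within 150000 nM to 1000000 nM.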

Compound 4, half-maximal cytotoxic concentration: > 300000 nM
Compound 4 gave a limit, no number; the forecaster's own chance of this, stated with the estimate: 85%; the middle value lies beyond the limit too.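

In this assay no new step can be read from compound 3 to compound 4, since both give only a limit rather than a number. The same holds across the whole set: the limit of > 300000 nM in this assay, at which 4 of the 4 values shown sit.

The compounds shown leave open how much of each one the cells tolerate, and whether the change from 4-fluorophenyl to 4-chlorophenyl makes any difference to that tolerance.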